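Fluoro step carried from one amide core to another

The compounds below may be only part of what the source reports. "The series", "measured", "known", "first", "only" and "open" are said of these compounds alone.

Compound 1 `O=C(Nc1nnc(-c2ccccc2)s1)c1cc(Cl)ccc1O` and compound 2 `O=C(Nc1nnc(-c2ccc(F)cc2)s1)c1cc(Cl)ccc1O` stand on one core; compound 3 `O=C(Nc1nnc(-c2ccccc2)s1)c1ccccc1` and compound 4 `O=C(Nc1nnc(-c2ccc(F)cc2)s1)c1ccccc1` stand on a second. In a functional assay on MCF7 cells (Homo sapiens) for antiproliferative activity, read by MTT assay, with a stated time of 48 h (a lower number here means a stronger inhibitor, a higher number a weaker inhibitor), compound 1 gives 1120 nM. In this assay compound 2 gives 750 nM. The change from the first to the second is fluoro in place of hydrogen on an aromatic carbon and it made a 1.5-fold lower number from compound 1 to compound 2 (0.17 log units; within the scatter). In this assay, within the data shown here, compound 3 gives 5870 nM, the highest number of the three measured so far; against compound 1 the gap is beyond the scatter, and so is the gap against compound 2. How the core of compound 3 differs from the core of compound 1 is not broken down here.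

Compound 4 carries the same change onto the second core: fluoro in place of hydrogen on an aromatic carbon. The description of the place is the same word for word in both pairs, so this is taken as the same change rather than merely the same kind. Among the measured compounds shown here, only one measured instance of the change exists, and it lies within the scatter, so little movement is expected; the expectation rests on a 1.5-fold lower number from compound 1 to compound 2 (0.17 log units; within the scatter) alone and is widened to allow for the shift of core. The expected step reads a 1.5-fold lower number from compound 3 to compound 4 (0.17 log units; within the scatter). Compound 4 is expected to give 4000 nM in this assay, with an expected range from 1900 nM to 9500 nM.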

Compound 4, half-maximal inhibitory concentration: 5350 nM
The estimate for compound 4 lay 1.3-fold (0.13 log units) below the measured number; measured number inside the range.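

On the second core, phenyl to 4-fluorophenyl in this assay gives a 1.1-fold lower number from compound 3 to compound 4 (0.04 log units; within the scatter), so the change leaves no readable mark on this core. The same change has now been seen on both cores, and the two steps do not differ by more than repeated measurement would allow: the same change on two cores in this assay, a 1.5-fold lower number (0.17 log units; within the scatter) from compound 1 to compound 2 and a 1.1-fold lower number (0.04 log units; within the scatter) from compound 3 to compound 4, 1.4-fold (0.13 log units) apart, within the scatter of two such steps. This shows that, across these two pairs, nothing separates the result of the change on one core from its result on the other, but it does not show that fluoro in place of hydrogen has any real effect on antiproliferative activity, and two steps this small make a weak test of transfer, since a core-dependent effect of modest size could lie hidden in the scatter and nothing here speaks for a third core.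

Still open, on these data alone, is whether another group on the same aromatic carbon, such as methoxy, a nitrile, an amine or a carboxylic acid, would give a step beyond the scatter on either core, which would offer a firmer test of whether a change carries from one core to the other. Also open, as far as these compounds go, is whether the same agreement between the two cores holds for this change outside this assay.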